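Trifluoromethyl in Place of Methoxycarbonyl on the Shared Core

A few compounds are considered here, and "the series" means these few. Any claim that something is new, unique, unknown or untested is made for them only; others in the source may bear on it.

Compound 2 `COC(=O)c1cc(NCc2ccccc2[N+](=O)[O-])c2cn[nH]c2c1` registers in an assay for inhibition of Tryptophan 2,3-dioxygenase (Homo sapiens), with stated times of 10 min and 60 min (a lower number here means a stronger inhibitor, a higher number a weaker inhibitor), only as a limit, > 100000 nM. Compound 3 `O=[N+]([O-])c1ccc2[nH]c(CNc3cc(C(F)(F)F)cc4[nH]ncc34)cc2c1` likewise reaches no more than a limit, > 100000 nM. Compound 1 `FC(F)(F)c1cc(NC[C@H]2CCCN2)c2cn[nH]c2c1` does give a number in this assay, 6090 nM. Compound 2 therefore sits at the limit of > 100000 nM in this assay, at which 2 of the 3 values shown sit, sharing that position with one other compound while one compound carries a measured value. Compound 4 `O=[N+]([O-])c1ccccc1CNc1cc(C(F)(F)F)cc2[nH]ncc12` differs from compound 2 by trifluoromethyl in place of methoxycarbonyl on an aromatic carbon. For the measured compounds named here, no measured pair makes this exact change, and compound 3 with the same trifluoromethyl stays at > 100000 nM, so little movement beyond the scatter is expected. Compound 4 is accordingly estimated at 60000 nM, probably between 15000 nM and 200000 nM, with the expected step being an at least 1.6-fold lower number from compound 2 to compound 4 (0.22 log units; that floor lies within the scatter).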

Compound 4, half-maximal inhibitory concentration: 2550 nM
Compound 4: the middle estimate sits 24-fold (1.37 log units) above what was measured; the measured number lies below the stated range.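

With the nitrobenzyl amine side chain held constant, the group on this aromatic carbon separates a limit from a measured value in this assay: trifluoromethyl in place of methoxycarbonyl gives an at least 39-fold lower number from compound 2 to compound 4 (1.59 log units; beyond the scatter). Compound 3 also carries trifluoromethyl, yet it gives > 100000 nM, which is a limit, so trifluoromethyl alone does not ensure a measured value. The step is only a floor, since compound 2 stands at a limit: the limit of > 100000 nM in this assay, at which 2 of the 4 values shown sit.

Still open, on these data alone, is whether a nitrile or a carboxylic acid on this aromatic carbon would act as trifluoromethyl does. This single pair also leaves open whether the same exchange would have a comparable effect with other side chains.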